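Amide nitrogen exchange on compound 2

A few compounds are considered here, and "the series" means these few. Any claim that something is new, unique, unknown or untested is made for them only; others in the source may bear on it.

In an ADME assay on MT4 cells (Homo sapiens) for cytotoxicity, read by MTT assay (on this read-out higher numbers stand for lower toxicity in this test and lower numbers for higher toxicity in this test), compound 1 (`Cc1cc(C)cc(S(=O)(=O)c2c(C(=O)NCC(=O)NC(C)c3ccccc3)[nH]c3ccc(Cl)cc23)c1`) gives 29400 nM, and compound 2 (`Cc1cc(C)cc(S(=O)(=O)c2c(C(=O)NC(C)C(=O)NC(C)c3ccccc3)[nH]c3ccc(Cl)cc23)c1`) gives 21700 nM. These two values lie within the scatter of each other, so compound 2 stands level with compound 1 on the numbers available. Compound 3 (`Cc1cc(C)cc(S(=O)(=O)c2c(C(=O)NC(C)C(=O)NCc3ccccc3F)[nH]c3ccc(Cl)cc23)c1`) carries 2-fluorobenzyl in place of 1-phenylethyl on an amide-type nitrogen. For the measured compounds named here, only one measured step exists, a 1.4-fold lower number from compound 1 to compound 2 (0.13 log units; within the scatter), and it places methyl for hydrogen on a saturated chain carbon, not on this nitrogen. Going by the values given here, it therefore bears on the new exchange only indirectly, and no measured step tests that exchange itself. With so little evidence, no shift beyond the scatter is expected in this assay. The expected change is a 1.1-fold higher number from compound 2 to compound 3 (0.04 log units; within the scatter). For compound 3 the estimated value is 24000 nM, with an expected range of 10000 nM to 60000 nM.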

Compound 3, half-maximal cytotoxic concentration: 23300 nM
Estimate against measurement, compound 3: 1.0-fold (0.01 log units) above, and the stated range covers the measured number.
By their numbers in this assay, from the lowest: compounds 2, 3 and 1 (each within the scatter of the next).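

In this assay, the amide-type nitrogen now has a reading of its own: 2-fluorobenzyl in place of 1-phenylethyl gives a 1.1-fold higher number from compound 2 to compound 3 (0.03 log units; within the scatter). For the compounds shown here, the earlier step concerned only the saturated chain carbon, so this is the only information on the nitrogen substituent, and it separates neither group from the other on this read-out. Both groups carry the same count of heavy atoms and one six-membered aromatic ring of carbon only, and nothing available explains why the two read alike.

Going by these compounds alone, the single exchange alters the fluorine and the chain together, so plain benzyl on this nitrogen would be needed to tell those two parts apart. Also open, from the compounds shown here alone, is how this read-out responds to a group of another kind at this position, such as a carboxylic acid or an amine.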